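Working notes: from compound 2 to compound 3

The compounds below may be only part of what the source reports. "The series", "measured", "known", "first", "only" and "open" are said of these compounds alone.

Measured in an ADME assay on WI-38 cells (Homo sapiens) for cytotoxicity, read by sulforhodamine B assay, with a stated time of 24 h; on this read-out lower numbers stand for stronger inhibition and higher numbers for weaker inhibition:
Compound 1 `O=C1Nc2ccc(S(=O)(=O)N3CCOCC3)cc2/C1=N/c1cccc(C(F)(F)F)c1` gives 226000 nM
Compound 2 `O=C1Nc2ccc(S(=O)(=O)N3CCOCC3)cc2/C1=N/NC(=O)c1ccccc1` gives 295000 nM

Among the compounds with values here, compound 2, at 295000 nM, lies within the scatter of compound 1, the only other measured number. Compound 3 `O=C1Nc2ccc(S(=O)(=O)N3CCOCC3)cc2/C1=N/c1ccc(C(=O)O)cc1` carries 4-carboxyphenyl in place of benzamido on a double-bonded nitrogen at that same place. Within the data shown here, one measured step bears on this: a 1.3-fold higher number from compound 1 to compound 2 (0.12 log units; within the scatter), a change at that nitrogen. Among the measured compounds shown here, no measured compound carries 4-carboxyphenyl, so the basis is thin. No step beyond the scatter is expected in this assay, and the estimated step is a 1.1-fold lower number from compound 2 to compound 3 (0.05 log units; within the scatter) here. Compound 3 is expected at 260000 nM, with an estimated range from 120000 nM to 500000 nM.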

Compound 3, half-maximal inhibitory concentration: 313000 nM
Estimate against measurement, compound 3: 1.2-fold (0.08 log units) below; the measured number falls inside the stated range.
By their numbers in this assay, from the lowest: compounds 1, 2 and 3 (each within the scatter of the next).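

In this assay, 4-carboxyphenyl on the double-bonded nitrogen gives a 1.1-fold higher number from compound 2 to compound 3 (0.03 log units; within the scatter) and a 1.4-fold higher number from compound 1 to compound 3 (0.14 log units; within the scatter). Both steps stay within the scatter, so 4-carboxyphenyl, benzamido and 3-(trifluoromethyl)phenyl cannot be told apart at this position, and the series now spans three different groups there without a separation in this read-out. Nothing measured speaks to an explanation for this result. Open, as far as these compounds go, is whether a simple amine or a longer alkyl chain on that nitrogen would give a step beyond the scatter. Changes elsewhere on the shared core also remain open.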